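The source may report more compounds than this note shows. Statements on the series, on what has been measured and on what is new or still open speak of the compounds shown alone.

Compounds measured so far:
- compound 1, `Cc1ccc(OCC(=O)N(Cc2cccs2)C2COC2)cc1`, 23000 nM
- compound 2, `Cc1ccc(OCC(=O)N(Cc2cccs2)C2CCCCC2)cc1`, 40000 nM
- compound 3, `Cc1ccc(OCC(=O)N(Cc2cccs2)c2ccon2)cc1`, 2 nM

These values come from an assay on HEK293 cells for agonist activity at transient receptor potential cation channel subfamily M member 8 (Homo sapiens), read by fluorescence and calcium flux, with a stated time of 15 min; on this read-out lower numbers stand for an effect already at smaller amounts and higher numbers for an effect only at larger amounts of compound. Compound 3 stands lowest of the three, and both its steps to the others lie beyond the scatter: a 12000-fold lower number from compound 1 to compound 3 (4.06 log units; beyond the scatter) and a 20000-fold lower number from compound 2 to compound 3 (4.30 log units; beyond the scatter). Between compound 1 and compound 2 the difference is small, a 1.7-fold higher number from compound 1 to compound 2 (0.24 log units; within the scatter).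

Compound 4, `COCCN(Cc1cccs1)C(=O)COc1ccc(C)cc1`, has not been measured. It differs from compound 3 in one place: 2-methoxyethyl in place of 1,2-oxazol-3-yl on an amide-type nitrogen. The two steps that bear on it are the ones from compound 1 and compound 2 to compound 3, which replace a non-aromatic group on the amide-type nitrogen with the 1,2-oxazol-3-yl and give large drops. Compound 4 carries a chain there again, so the expected step is the reverse of those, a large rise in this assay: a 10000-fold higher number from compound 3 to compound 4 (4.00 log units; beyond the scatter). Compound 4 is therefore estimated at 20000 nM, in the range 3000 nM to 100000 nM.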

Compound 4, half-maximal effective concentration: 400 nM
The estimate for compound 4 lay 50-fold (1.70 log units) above the measured number; measured number below the stated range.
By their numbers in this assay, from the lowest: compound 3; then compound 4; then compounds 1 and 2 (each within the scatter of the next).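

In this assay, the non-aromatic groups on the amide-type nitrogen no longer fall together: cyclohexyl and oxetan-3-yl lay within the scatter of each other, but 2-methoxyethyl stands apart from both, with a 100-fold lower number from compound 2 to compound 4 (2.00 log units; beyond the scatter) and a 58-fold lower number from compound 1 to compound 4 (1.76 log units; beyond the scatter). The change away from 1,2-oxazol-3-yl is still large, at a 200-fold higher number from compound 3 to compound 4 (2.30 log units; beyond the scatter), so compound 3 keeps the lowest number, yet compound 4 shows that a group without a ring can recover a good part of the gap. Nothing at hand explains this difference among the non-aromatic groups.

The compounds shown leave open whether a plain butyl chain, with carbon in place of the chain oxygen, would stand with compound 4 or nearer compound 1 and compound 2. They also leave open whether a phenyl ring on this nitrogen would come close to compound 3.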